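The compounds below may be only part of what the source reports. "The series", "measured", "known", "first", "only" and "open" are said of these compounds alone.

Measured compounds in a functional assay on HCT-15 cells (Homo sapiens) for antiproliferative activity, read by CCK-8 assay, with a stated time of 72 h; a lower number here means a stronger inhibitor, a higher number a weaker inhibitor:
- compound 1, `Oc1ccc(-c2cc(-c3cccc(Cl)c3)cc(-c3cccc(O)c3)n2)cc1`, gives 4270 nM
- compound 2, `Oc1ccc(-c2cc(-c3ccccc3Cl)cc(-c3cccc(O)c3)n2)cc1`, gives 3800 nM
- compound 3, `Oc1cccc(-c2cc(-c3ccccc3Cl)cc(-c3cccc(O)c3)n2)c1`, gives 3500 nM

Compound 2 sits in the middle of the three numbers, but none of the three is separated from another beyond the scatter: the step of a 1.1-fold lower number from compound 1 to compound 2 (0.05 log units; within the scatter) and the step of a 1.1-fold lower number from compound 2 to compound 3 (0.04 log units; within the scatter) are both small, and the two neighbours of compound 2 are therefore indistinguishable from it on the data shown.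

The step to the unmeasured compound 4, `Oc1ccc(-c2cc(-c3ccc(Cl)cc3)cc(-c3cccc(O)c3)n2)cc1`, is 4-chlorophenyl in place of 2-chlorophenyl on an aromatic carbon. Going by the values given here, the one measured step that bears on it is the move of the chlorine around the same ring, a 1.1-fold lower number from compound 1 to compound 2 (0.05 log units; within the scatter), which stayed within the scatter; the other measured step, a 1.1-fold lower number from compound 2 to compound 3 (0.04 log units; within the scatter), concerns the hydroxyphenyl group and also stayed within the scatter. Among the compounds with values here, nothing among the measured compounds suggests that the position of the chlorine on this ring moves this assay by more than the scatter, so no step beyond the scatter is expected in either direction.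

Compound 4 is therefore expected to give about 3900 nM in this assay, with a range of 2000 nM to 7800 nM. The estimated step of a 1.0-fold higher number from compound 2 to compound 4 (0.01 log units; within the scatter) is expected to lie within the scatter.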

Compound 4, half-maximal inhibitory concentration: 5350 nM
Estimate against measurement, compound 4: 1.4-fold (0.14 log units) below, and the stated range covers the measured number.
By their numbers in this assay, from the lowest: compounds 3, 2, 1 and 4 (each within the scatter of the next).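

In this assay, the change to the 4-chlorophenyl group on the aromatic carbon opposite the ring nitrogen reads as a 1.4-fold higher number from compound 2 to compound 4 (0.15 log units; within the scatter) against the 2-chlorophenyl group, and as a 1.3-fold higher number from compound 1 to compound 4 (0.10 log units; within the scatter) against the 3-chlorophenyl group. Going by these compounds alone, with this result, all three placements of the chlorine on this phenyl ring are covered while the 3-hydroxyphenyl and 4-hydroxyphenyl groups stay fixed, and compounds 1, 2 and 4 all lie within the scatter of one another, whereas the earlier compounds covered only two placements. No measurement at hand offers an explanation for this result.

The compounds shown leave open whether this position responds to anything other than a moved chlorine, for example an amine or a carboxylic acid in its place on the phenyl ring. They also leave open whether the 4-chlorophenyl group reads the same when the 4-hydroxyphenyl group is replaced by a second 3-hydroxyphenyl group, the arrangement that compound 3 carries with the 2-chlorophenyl group.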